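The source may hold more compounds than are shown below. What is called first, only, known or untested is meant among the compounds shown, and "the series" means these compounds.

In an ADME assay on L1210 cells (Mus musculus) for cytotoxicity, with a stated time of 48 h (on this read-out higher numbers stand for weaker inhibition and lower numbers for stronger inhibition), compound 1 `C=C1[C@H](C)CCC[C@]1(C)CC/C(C)=C/CC1=C(O)C(=O)C=C(N[C@H](CO)C(=O)O)C1=O` gives 2.6 ug/mL and compound 2 `CC1=CCC[C@](C)(CC/C(C)=C/CC2=C(O)C(=O)C=C(N[C@@H](C(=O)O)C(C)C)C2=O)[C@@H]1C` gives 3 ug/mL, two values within the scatter of each other. Compound 3 `CC1=CCC[C@](C)(CC/C(C)=C/CC2=C(O)C(=O)C=C(N[C@H](CO)C(=O)O)C2=O)[C@@H]1C` gives > 10 ug/mL, which is a limit of the assay. Compound 4 `C=C1[C@H](C)CCC[C@]1(C)CC/C(C)=C/CC1=C(O)C(=O)C=C(N[C@H](C(=O)O)[C@H](C)O)C1=O` departs from compound 1 on the amine nitrogen: 1-carboxy-2-hydroxypropyl in place of 1-carboxy-2-hydroxyethyl on an amine nitrogen. Among the measured compounds shown here, no measured step makes this exact change. The closest is an at least 3.3-fold higher number from compound 2 to compound 3 (0.52 log units; beyond the scatter), which alters the group on that same nitrogen and shows that this group can matter. The other, an at least 3.8-fold higher number from compound 1 to compound 3 (0.58 log units; beyond the scatter), leaves that group unchanged and alters the structure elsewhere. With so limited a change, the expected result is a 1.2-fold higher number from compound 1 to compound 4 (0.06 log units; within the scatter), nothing beyond the scatter. For compound 4 the estimated value is 3 ug/mL, with an expected range of 1.3 ug/mL to 7.5 ug/mL.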

Compound 4, half-maximal inhibitory concentration: > 10 ug/mL
Compound 4 was reported as a limit; the forecaster's own chance of this, stated with the estimate: 12%; middle value at least 3.3-fold (0.52 log units) away from the limit.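

In this assay there is an at least 3.8-fold higher number from compound 1 to compound 4 (0.58 log units; beyond the scatter), so on the core of compound 1 the group on the amine nitrogen matters, and the change from 1-carboxy-2-hydroxyethyl to 1-carboxy-2-hydroxypropyl, with one more carbon and a second defined stereocentre, is enough to give a step beyond the scatter. The value of compound 4 is a limit, so the full size of this step stays unknown: the limit of > 10 ug/mL in this assay, at which 2 of the 4 values shown sit.

Whether the added carbon or the added stereocentre accounts for the step remains open. So does how an amine or a longer chain on that nitrogen would read out on this core.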